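A few compounds are considered here, and "the series" means these few. Any claim that something is new, unique, unknown or untested is made for them only; others in the source may bear on it.

Measured so far in a functional assay on CAKI-1 cells (Homo sapiens) for inhibition, read by sulforhodamine B assay, with a stated time of 48 h, tested at 10 uM; a higher number here means a weaker effect of the compound at the concentration tested, a lower number a stronger effect:
compound 1, `COc1cc(Cl)cc(-c2nn(-c3cccc(NC(=O)Nc4cccc(C(F)(F)F)c4)c3)cc2-c2ccncc2)c1`, gives 16.1%
compound 2, `COc1cc(Cl)cc(-c2nn(-c3cccc(NC(=O)c4cccc(C(F)(F)F)c4)c3)cc2-c2ccncc2)c1`, gives 54%
compound 3, `O=C(Nc1cccc(-n2cc(-c3ccncc3)c(-c3cc(O)cc(Cl)c3)n2)c1)c1cc(C(F)(F)F)cc(C(F)(F)F)c1`, gives 58.5%

Compound 3 stands at the highest number of the three, which in this assay means the weakest effect at the concentration tested; compound 2 sits within the usual scatter of it, while compound 1 lies well below, beyond the scatter. Compound 4, `COc1cc(Cl)cc(-c2nn(-c3cccc(NC(=O)c4cc(C(F)(F)F)cc(C(F)(F)F)c4)c3)cc2-c2ccncc2)c1`, differs from compound 3 in one place: methyl in place of hydrogen on an oxygen on an aromatic ring. Within the data shown here, the only measured step, a number 37.9 percentage points higher from compound 1 to compound 2 (beyond the scatter), concerns the carbonyl side of the molecule and says nothing about a change at the hydroxy group. Among the measured compounds shown here, with no step on record that bears on this change, compound 4 is expected to stay close to compound 3, a move of a number 0.5 percentage points lower from compound 3 to compound 4 (within the scatter). The estimate for compound 4 is therefore 58%, with a range from 40% to 76%.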

Compound 4, a percentage reported as activity, at one concentration (the size of the read-out at that concentration, not a potency): 68.6%
Compound 4: the middle estimate sits 10.6 percentage points below what was measured, within the range that was stated.
By their numbers in this assay, from the lowest: compound 1; then compounds 2 and 3 (each within the scatter of the next); then compound 4.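

In this assay, among these compounds, methyl on the oxygen of the 3-chloro-5-hydroxyphenyl group weakens the effect (a number 10.1 percentage points higher from compound 3 to compound 4 (beyond the scatter)), the first view of any change at this position. At the other end of the molecule, a second trifluoromethyl also weakens it (a number 14.6 percentage points higher from compound 2 to compound 4 (beyond the scatter)), so the hydroxy compound 3 does not stand out as the weakest of the set. Nothing at hand explains either step.

As far as these compounds go, what an amine or a longer chain such as ethoxy would give in place of methoxy remains open. So does whether the methoxy step would hold with only one trifluoromethyl present.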